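From 3-bromophenyl to 4-cyanophenyl on a shared core

The source may report more compounds than this note shows. Statements on the series, on what has been measured and on what is new or still open speak of the compounds shown alone.

Of the compounds shown here, three sharing one core have been tested so far in a functional assay on L1210 cells (Mus musculus) for inhibition (on this read-out higher numbers stand for weaker inhibition and lower numbers for stronger inhibition), and give a small picture. Compound 1 (`C#CCN(Cc1ccc2nc(C)nc(O)c2c1)c1ccccc1`) reads > 6500 nM here, which is a limit of the assay and not a number. Compound 2 (`C#CCN(Cc1ccc2nc(C)nc(O)c2c1)c1cccc(CC)c1`) gives 5000 nM and compound 3 (`C#CCN(Cc1ccc2nc(C)nc(O)c2c1)c1cccc(Br)c1`) gives 1800 nM as the lowest number of the set.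

Compound 4 (`C#CCN(Cc1ccc2nc(C)nc(O)c2c1)c1ccc(C#N)cc1`) is still unmeasured, and it carries 4-cyanophenyl in place of 3-bromophenyl on an amine nitrogen. For the measured compounds named here, three measured steps bear on this group. Bromo in place of hydrogen brings an at least 3.6-fold lower number from compound 1 to compound 3 (0.55 log units; beyond the scatter) and ethyl in place of hydrogen brings an at least 1.3-fold lower number from compound 1 to compound 2 (0.11 log units; that floor lies within the scatter) as a much less certain change. Bromo in place of ethyl brings a 2.8-fold lower number from compound 2 to compound 3 (0.44 log units; beyond the scatter) as a modest step. Going by the values given here, no measured compound carries a 4-cyanophenyl group, and these steps guide only loosely.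

Compound 4 has no bromo group, and for compound 3 the closest guide to what that group is worth is a 2.8-fold lower number from compound 2 to compound 3 (0.44 log units; beyond the scatter) in size. A modest step toward weaker inhibition is therefore expected (a 1.9-fold higher number from compound 3 to compound 4 (0.29 log units; within the scatter)) with real uncertainty. For compound 4 the estimated value is 3500 nM with an expected range from 1200 nM to 10000 nM as the likely span.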

Compound 4, half-maximal inhibitory concentration: > 5000 nM
Compound 4: a limit, no number; the forecaster's own chance of this, stated with the estimate: 30%; middle value at least 1.4-fold (0.15 log units) away from the limit.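

Compound 4 gives a limit rather than a number in this assay: the limit of > 5000 nM in this assay, at which 1 of the 4 values shown sits. Even so, 4-cyanophenyl in place of 3-bromophenyl on the amine nitrogen brings an at least 2.7-fold higher number from compound 3 to compound 4 (0.44 log units; beyond the scatter), so the lower number seen with compound 3 does not carry over to this nitrile-bearing ring. The step to compound 4 from compound 1 cannot be read, as the two limits leave its size open, and the result therefore does not rank compound 4 against compound 1.

As far as these compounds go, compound 4 differs from compound 3 in both the group and the number in its name, 4 rather than 3, so the step cannot show whether the nitrile itself or its place on the ring matters more. 4-Cyanophenyl in place of 3-ethylphenyl on the amine nitrogen brings a number no lower from compound 2 to compound 4 (the limit leaves the size open), and it also remains open whether a chloro, methoxy or carboxylic acid group on the phenyl ring would give a number near that of compound 3, or whether a 3-cyanophenyl group would give a measurable number rather than a limit.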